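Swapping the Sulfonamide Amine: Compound 1 to Compound 4

The compounds below may be only part of what the source reports. "The series", "measured", "known", "first", "only" and "open" are said of these compounds alone.

Compound 1 `O=C(Nc1cccc(S(=O)(=O)N2CCCC2)c1)c1cccnc1N1CCC2(CC1)CC2`: > 399 mL.min-1.g-1 in an ADME assay on microsomes from liver (Homo sapiens) for metabolic stability, read by LC-MS, with a stated time of 40 min, tested at 0.5 uM; a higher number here means faster removal of the compound, a lower number slower removal
Compound 2 `CC(C)(C)NS(=O)(=O)c1cccc(NC(=O)c2ccc(NC(C)(C)CO)nc2N2CCC3(CC2)CC3)n1`: > 399 mL.min-1.g-1
Compound 3 `O=C(Nc1cccc(S(=O)(=O)N2CCCCC2)c1)c1cn[nH]c1-c1ccc(Cl)cc1`: 255 mL.min-1.g-1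

The value for compound 1 is a limit of this assay, not a number. The value for compound 2 is likewise a limit. Compound 3 is the only one of the three with a number, and it too sits high. Compound 1 therefore stands with compound 2 at the limit (the limit of > 399 mL.min-1.g-1 in this assay, at which 2 of the 3 values shown sit), and nothing here separates the two.

Compound 4 `O=C(Nc1cccc(S(=O)(=O)NC2CC2)c1)c1cccnc1N1CCC2(CC1)CC2` differs from compound 1 in one place: cyclopropylamino in place of pyrrolidin-1-yl on a sulfonyl sulfur. Among the compounds with values here, no step between measured compounds is known, so the effect of this change cannot be read from the data. Compound 4 is expected to stay near the limit, with the step of an at least 1.1-fold lower number from compound 1 to compound 4 (0.04 log units; that floor lies within the scatter) lying within the usual scatter or slightly downward. The estimate for compound 4 is 360 mL.min-1.g-1, between 180 mL.min-1.g-1 and 420 mL.min-1.g-1.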

Compound 4, intrinsic clearance in microsomes: > 399 mL.min-1.g-1
Compound 4 was reported as a limit; the forecaster's own chance of this, stated with the estimate: 55%; middle value at least 1.1-fold (0.04 log units) from the limit.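

Within the data shown here, compound 1 and compound 4 both sit at a limit of this assay rather than at a number, so no step between them can be read: the limit of > 399 mL.min-1.g-1 in this assay, at which 3 of the 4 values shown sit. The compounds shown leave open whether cyclopropylamino in place of pyrrolidin-1-yl changes intrinsic clearance in microsomes at all.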